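This account rests on a few compounds, and the source may have more. Where it says the series, first, only, none or still open, it means among the compounds named here.

Compound 1 `O=C(/C=C/c1ccccc1O)CC(=O)/C=C/c1cc(O)ccc1O` and compound 2 `O=C(/C=C/c1cccc(O)c1)CC(=O)/C=C/c1cc(O)ccc1O` are built on the same core and differ in one place only: 3-hydroxyphenyl in place of 2-hydroxyphenyl on a double-bonded chain carbon bound to a double-bonded chain carbon. In a functional assay, with a stated time of 30 min (a lower number here means a stronger inhibitor, a higher number a weaker inhibitor), compound 1 gives 48000 nM, while compound 2 gives 88000 nM, a move of a 1.8-fold higher number from compound 1 to compound 2 (0.26 log units; within the scatter). Compound 3 `O=C(/C=C/c1ccccc1O)CC(=O)c1ccc(O)c(O)c1` gives 16000 nM in this assay, the lowest of the three numbers, and its gaps to compound 1 and to compound 2 both lie beyond the scatter. The difference between the core of compound 3 and that of compound 1 is not broken down here. Compound 4 `O=C(/C=C/c1cccc(O)c1)CC(=O)c1ccc(O)c(O)c1` has not yet been measured in this assay; it differs from compound 3 by 3-hydroxyphenyl in place of 2-hydroxyphenyl on a double-bonded chain carbon bound to a double-bonded chain carbon, which is the same change already seen between compound 1 and compound 2. Because that earlier change gave only a 1.8-fold higher number from compound 1 to compound 2 (0.26 log units; within the scatter), compound 4 is expected to show a step of a 1.8-fold higher number from compound 3 to compound 4 (0.24 log units; within the scatter), again inside the scatter. Compound 4 is thus estimated at 28000 nM in this assay, with a likely range from 12000 nM to 70000 nM.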

Compound 4, half-maximal inhibitory concentration: 10000 nM
Beside the measured number, compound 4's estimate is 2.8-fold (0.45 log units) above it; measured number outside the range, below it.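

Placing 3-hydroxyphenyl where 2-hydroxyphenyl stood gives a 1.6-fold lower number from compound 3 to compound 4 (0.20 log units; within the scatter) in this assay, a step that on its own is no clear move, yet set beside the earlier step it does not repeat it: the same change on two cores in this assay, a 1.8-fold higher number (0.26 log units; within the scatter) from compound 1 to compound 2 and a 1.6-fold lower number (0.20 log units; within the scatter) from compound 3 to compound 4, 2.9-fold (0.47 log units) apart, beyond the scatter of two such steps. This shows that, on these two cores, the change did not carry over as a fixed step, so a step read on one core was a poor guide to the other. For the compounds shown here, it does not show why the two cores differ, and with only two pairs, each step within the scatter on its own, it gives no rule for which way the change would go on a further core.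

The compounds shown leave open what happens when an amine or a carboxylic acid stands in place of the hydroxyl on the phenyl ring, or when a longer chain replaces the one these compounds share. They also leave open how the same change reads on any core beyond these two.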